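The compounds below may be only part of what the source reports. "The series", "measured", "known", "first", "only" and "open" are said of these compounds alone.

Working notes, series around a shared core.

Three compounds carry a number in an assay on cell membranes for displacement of a labelled ligand from corticotropin-releasing factor receptor 1 (Rattus norvegicus); a higher number here means a weaker inhibitor, a lower number a stronger inhibitor. Compound 1 `CCCCN(CCC)c1nc(C)nc2c(-c3c(C)cc(N(C)C)nc3C)c(C)nn12` gives 12.8 nM, compound 2 `CCCCN(CCC)c1nc(C)nc2c(-c3ccc(OC)nc3C)c(C)nn12` gives 2.4 nM, and compound 3 `CCC(CC)Nc1nc(C)nc2c(-c3cnc(N(C)C)cc3C)c(C)nn12` gives 24.8 nM. Compound 2 stands lowest of the three; its gaps to compound 1 and to compound 3 both lie beyond the scatter, so it is the strongest inhibitor of the measured set.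

Compound 4 `CCN(CC)c1nc(C)nc2c(-c3ccc(OC)nc3C)c(C)nn12` is not yet measured. Against compound 2 the change is diethylamino in place of butyl(propyl)amino on an aromatic carbon. Within the data shown here, no measured pair isolates this change, so the size of its effect is open. A modest weakening is expected: the step from compound 2 to compound 4 is estimated at a 2.5-fold higher number from compound 2 to compound 4 (0.40 log units; beyond the scatter). For compound 4 in this assay the estimate is 6 nM, with a range from 2 nM to 20 nM.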

Compound 4, half-maximal inhibitory concentration: 12 nM
Compound 4: the middle estimate sits 2.0-fold (0.30 log units) below what was measured; the range from low to high includes it.
By their numbers in this assay, from the lowest: compound 2; then compounds 4, 1 and 3 (each within the scatter of the next, the first and the last beyond it).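

In this assay, the position between two ring nitrogen atoms now has its first readable step: diethylamino in place of butyl(propyl)amino gives a 5.0-fold higher number from compound 2 to compound 4 (0.70 log units; beyond the scatter). The change removes carbon only, with hydrogen-bond donors and acceptors counted the same, so the number at this position responds to the amine's alkyl chains alone. Nothing available explains the size of this step.

As far as these compounds go, whether dibutylamino or a chain carrying an ether oxygen would give a lower number remains open. One step also cannot show whether the effect carries over to other groups on the shared core.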